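Aryl swap on the propanamide chain of the piperazine series

The source may report more compounds than this note shows. Statements on the series, on what has been measured and on what is new or still open speak of the compounds shown alone.

Two compounds of the series have numbers in an assay on HEK293 cells for displacement of a labelled ligand from Melanocortin receptor 4 (Homo sapiens); on this read-out higher numbers stand for weaker inhibition and lower numbers for stronger inhibition. Compound 1 `Cc1cccc(CCC(=O)N2CCN(c3ccc(C(F)(F)F)cc3[C@@H](N)CC(C)C)CC2)c1` gives 2100 nM, and compound 2 `COc1ccc(CCC(=O)N2CCN(c3ccc(C(F)(F)F)cc3[C@@H](N)CC(C)C)CC2)cc1` gives 350 nM. Among the measured compounds shown here, compound 2 therefore holds the lower of the two values, its nearest neighbour being compound 1, and the only measured step, a 6.0-fold lower number from compound 1 to compound 2 (0.78 log units; beyond the scatter), shows that the aryl group on the saturated chain carbon, two bonds along the chain from a carbonyl carbon, moves the number by a clear margin.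

Compound 3 `CC(C)C[C@H](N)c1cc(C(F)(F)F)ccc1N1CCN(C(=O)CCc2c(Cl)cccc2Cl)CC1` carries the change (2,6-dichlorophenyl in place of 4-methoxyphenyl on a saturated chain carbon, two bonds along the chain from a carbonyl carbon). For the measured compounds named here, the one step at hand bears on the same position but not on this pair of groups, and no other aryl variant is measured. A shift in this assay of the size seen from compound 1 to compound 2 is plausible in either direction; since compound 2 is the lower value of the two, the expected step of a 2.0-fold higher number from compound 2 to compound 3 (0.30 log units; within the scatter) is placed towards a somewhat higher number with wide uncertainty. For compound 3 the estimate in this assay is 700 nM, with a range from 150 nM to 3500 nM.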

Compound 3, inhibition constant: 2600 nM
Compound 3: middle estimate off by 3.7-fold (0.57 log units), on the low side, and the stated range covers the measured number.
By their numbers in this assay, from the lowest: compound 2; then compounds 1 and 3 (each within the scatter of the next).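

In this assay, 2,6-dichlorophenyl in place of 4-methoxyphenyl at this saturated chain carbon gives a 7.4-fold higher number from compound 2 to compound 3 (0.87 log units; beyond the scatter), so a second replacement of 4-methoxyphenyl, after the step from compound 1 to compound 2, also separates from compound 2 by more than the scatter. The step of a 1.2-fold higher number from compound 1 to compound 3 (0.09 log units; within the scatter) stays within the scatter, which leaves 3-methylphenyl and 2,6-dichlorophenyl indistinguishable on this read-out, and among the three aryl groups shown only the 4-methoxyphenyl of compound 2 stands apart. No measurement at hand accounts for this difference between the aryl groups.

The compounds shown leave open whether the lower number of compound 2 belongs to the methoxy group or to its place on the ring, a question that 3-methoxyphenyl, 4-methylphenyl and 4-chlorophenyl on the same chain would address. Also open, from the compounds shown here alone, is how an unsubstituted phenyl, or a longer chain between the carbonyl and the 4-methoxyphenyl, would read against these three compounds.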